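The source may report more compounds than this note shows. Statements on the series, on what has been measured and on what is new or still open speak of the compounds shown alone.

Of the compounds shown here, two with a shared core have been measured in a functional assay on WI-38 VA13 cells (Homo sapiens) for cytotoxicity; a lower number here means that less compound is needed, a higher number that more compound is needed for the effect. Compound 1, `Cc1ccc(C(=O)Nc2ccc3nc(NC(=O)C4CCCCC4)sc3c2)cc1`, carries a cyclohexyl amide on one side of the core and a methyl-substituted benzamide on the other; in this assay compound 1 gives 5.1 ug/mL. Compound 2, `CCCOC(=O)Nc1nc2ccc(NC(=O)c3c(Cl)cccc3Cl)cc2s1`, carries a propyl carbamate in place of the cyclohexyl amide and a dichlorobenzamide in place of the methylbenzamide; in this assay compound 2 gives 0.0025 ug/mL. That is the lower of the two numbers, and the gap to compound 1 lies well beyond the usual scatter. Since compound 1 and compound 2 differ in more than one place, no single change can be held responsible for the gap; the two values simply show where each compound stands.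

Compound 3, `CCCCCCNC(=O)Nc1nc2ccc(NC(=O)c3c(Cl)cccc3Cl)cc2s1`, has not yet been measured. It differs from compound 2 in one place: hexylamino in place of propoxy on a carbonyl carbon. Among the compounds with values here, no measured pair shows what this kind of change does, so the expectation rests on compound 2 alone. A modest step toward a higher number is expected, a 4.0-fold higher number from compound 2 to compound 3 (0.60 log units; beyond the scatter), with wide uncertainty. For compound 3 in this assay the expected value is 0.01 ug/mL, within a range from 0.001 ug/mL to 0.1 ug/mL.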

Compound 3, half-maximal effective concentration: 0.29 ug/mL
Estimate against measurement, compound 3: 29-fold (1.46 log units) below, and the stated range ends below it.
By their numbers in this assay, from the lowest: compound 2; then compound 3; then compound 1.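

Within the data shown here, with the dichlorobenzamide side held fixed, this is the first comparison that differs in only one place. In this assay, hexylamino in place of propoxy on the carbonyl carbon gives a 120-fold higher number from compound 2 to compound 3 (2.06 log units; beyond the scatter), so this position is far from indifferent to what is attached there. The swap changes two things at once, though: the atom bonded to the carbonyl carbon goes from oxygen to nitrogen, which adds a hydrogen-bond donor, and the chain goes from propyl to hexyl, and nothing available explains why the number rises so sharply.

Among these compounds, the single step therefore cannot be divided between the linking atom and the chain: propylamino would keep the chain of compound 2 with the nitrogen of compound 3, while hexyloxy would keep the oxygen of compound 2 with the chain of compound 3. On these data alone, how the number follows chain length in either direction also remains open, from a short group such as methoxy to a longer chain such as octylamino, as does the effect of a ring at this position, such as cyclohexylamino.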